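From compound 2 to compound 3, one change on the alkyne

A few compounds are considered here, and "the series" means these few. Any claim that something is new, unique, unknown or untested is made for them only; others in the source may bear on it.

Compound 1 `COc1ncnc2c1ncn2C[C@@H]1C[C@H](O)c2ccccc21` and compound 2 `O=c1[nH]c(=O)n([C@H]2C[C@H](O)[C@@H](CO)O2)cc1C#CCO` were both tested in an ADME assay on L1210/0 cells (Mus musculus) for cytotoxicity, with a stated time of 48 h; a lower number here means a stronger inhibitor, a higher number a weaker inhibitor. For compound 1 the reading is a limit of the assay, > 200000 nM. For compound 2 the reading is likewise a limit of the assay, > 200000 nM. Compound 2 thus stands at the limit of > 200000 nM in this assay, at which 2 of the 2 values shown sit. Compound 3 `C=CC#Cc1cn([C@H]2C[C@H](O)[C@@H](CO)O2)c(=O)[nH]c1=O` differs from compound 2 by vinyl in place of hydroxymethyl on a triple-bonded carbon. Among the measured compounds shown here, no measured pair of compounds differs in a single place, so no measured step guides the size of this change. The step of a number no higher from compound 2 to compound 3 (the limit leaves the size open) is expected to be none beyond the scatter. Compound 3 is therefore expected to give about 200000 nM, within 50000 nM to 1000000 nM.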

Compound 3, half-maximal inhibitory concentration: > 200000 nM
Compound 3 gave a limit, no number; the forecaster's own chance of this, stated with the estimate: 80%; the middle value lies on the limit itself.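

Among the compounds shown here, compound 2 and compound 3 both give only a limit in this assay, so no step between them can be read. The compounds shown leave open whether vinyl in place of hydroxymethyl changes the read-out at all.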